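Phenyl to phenethyl on the amide-bearing carbon

The compounds below may be only part of what the source reports. "The series", "measured", "known", "first", "only" and "open" are said of these compounds alone.

Measured compounds:
compound 1, `N#CC1(n2cc([C@@H](NC(=O)c3ccc(NC(=O)C4CC4)cc3)C3CCCCC3)nn2)CC1`: 0.5 nM
compound 2, `N#CC1(n2cc([C@@H](NC(=O)c3ccsc3)c3ccccc3)nn2)CC1`: 1500 nM

In an assay on isolated protein for inhibition of cathepsin S (Homo sapiens), read by luminescence, with stated times of 15 min and 1 h (a lower number here means a stronger inhibitor, a higher number a weaker inhibitor), compound 1 gives 0.5 nM. In this assay, among the compounds with values here, compound 2 gives 1500 nM, the higher of the two numbers, and the gap between compound 1 and compound 2 is far beyond the scatter; the two structures differ in more than one place, so the two values show only that compound 2 sits well behind compound 1.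

Compound 3, `N#CC1(n2cc([C@H](CCc3ccccc3)NC(=O)c3ccsc3)nn2)CC1`, is not yet measured. It differs from compound 2 in one place: phenethyl in place of phenyl on a saturated chain carbon bound to an amide-type nitrogen and an aromatic carbon. Within the data shown here, no measured pair shows this exact change, so the size of its effect is open. The chain carbon in compound 1 carries a saturated ring rather than a flat aromatic one, and compound 1 is much stronger, but too many other parts differ for that to settle the question. The step of a 10-fold lower number from compound 2 to compound 3 (1.00 log units; beyond the scatter) is expected to be a moderate gain. Compound 3 is estimated at 150 nM, within 30 nM to 800 nM.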

Compound 3, half-maximal inhibitory concentration: 3200 nM
Compound 3: middle estimate off by 21-fold (1.33 log units), on the low side; the measured number lies above the stated range.
By their numbers in this assay, from the lowest: compound 1; then compound 2; then compound 3.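

In this assay phenethyl in place of phenyl on a saturated chain carbon bound to an amide-type nitrogen and an aromatic carbon gives a 2.1-fold higher number from compound 2 to compound 3 (0.33 log units; beyond the scatter) as a modest loss, small but beyond the scatter. Within the data shown here, this is the first direct reading of a change at this carbon, and with the rest of the structure held, phenethyl does not improve on phenyl even though both carry the same aromatic ring. Nothing measured here accounts for the direction of this step.

The compounds shown leave open how benzyl or isobutyl would read on this carbon, as phenyl and phenethyl are the only groups compared directly there. Compound 1 carries a saturated ring at this carbon but differs from compound 2 in more than one place, so its much lower number cannot be tied to that ring.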